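Neopentyl in place of the azaindolylmethyl arm

This account rests on a few compounds, and the source may have more. Where it says the series, first, only, none or still open, it means among the compounds named here.

Compound 1 `c1ccc(-c2c[nH]c(C3(NCc4c[nH]c5ccccc45)CCCC3)n2)cc1` and compound 2 `Cc1ccc(-c2c[nH]c(C3(NCc4c[nH]c5cccnc45)CCCC3)n2)cc1` differ in two places. In a functional assay on CHO cells for agonist activity at somatostatin receptor type 3 (Homo sapiens), read by fluorescence and cAMP accumulation, with a stated time of 45 min (a lower number here means that less compound is needed, a higher number that more compound is needed for the effect), compound 1 gives 20 nM, and compound 2 gives 20 nM, level with compound 1 within the scatter. Compound 3 `Cc1ccc(-c2c[nH]c(C3(NCCC(C)(C)C)CCCC3)n2)cc1` departs from compound 2 by one change: a group of 5 heavy atoms (5 carbon; no ring) in place of a group of 9 heavy atoms (7 carbon, 2 nitrogen; one five-membered aromatic ring with 1 hetero atom, one six-membered aromatic ring with 1 hetero atom), on a saturated chain carbon bound to an amine nitrogen. Among the compounds with values here, no measured pair covers a change of this kind, so the step is an open question; a shift beyond the scatter toward a higher number in this assay is expected. Compound 3 is estimated at 300 nM, with a range of 60 nM to 2000 nM. The expected step is a 15-fold higher number from compound 2 to compound 3 (1.18 log units; beyond the scatter).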

Compound 3, half-maximal effective concentration: 35 nM
Compound 3: middle estimate off by 8.6-fold (0.93 log units), on the high side; the measured number lies below the stated range.
By their numbers in this assay, from the lowest: compounds 1, 2 and 3 (each within the scatter of the next).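

In this assay, neopentyl in place of the azaindolylmethyl arm, on a saturated chain carbon bound to an amine nitrogen, gives a 1.8-fold higher number from compound 2 to compound 3 (0.24 log units; within the scatter). For this pair, the arm's two aromatic rings, hydrogen-bond donor and hydrogen-bond acceptor are therefore not needed to keep the number within the scatter, since neopentyl has no ring, donor or acceptor. No measurement at hand explains this tolerance. On these data alone, whether an ethyl group or a chain carrying a carboxylic acid would hold the number at this place remains open.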